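The source may hold more compounds than are shown below. What is called first, only, known or untested is meant among the compounds shown, and "the series" means these compounds.

Measured in a functional assay on SF-268 cells (Homo sapiens) for cytotoxicity, read by sulforhodamine B assay, with a stated time of 48 h; a lower number here means a stronger inhibitor of growth, a higher number a weaker inhibitor of growth:
compound 1 `ClCc1cccc(Cn2cnc3ncnc(Cl)c32)c1` gives 3460 nM
compound 2 `ClCc1ccc(Cn2cnc3nc(Cl)nc(Cl)c32)cc1` gives 3980 nM
compound 3 `ClCc1cccc(Cn2cnc3c(Cl)nc(Cl)nc32)c1` gives 6600 nM

Compound 2 has the second highest of the three numbers; compound 1 is its nearest neighbour and compound 3 its furthest, and both gaps lie within the scatter, so the three values cannot be ordered. Compound 4 `ClCc1ccc(Cn2cnc3ncnc(Cl)c32)cc1` is not yet measured. It differs from compound 2 by hydrogen in place of chloro on an aromatic carbon, the change sitting between two ring nitrogen atoms, meta to a chloro group, meta to a fused ring and para to a fused ring. For the measured compounds named here, no step between measured compounds isolates this change, and all three measured values sit together; the step in this assay is therefore expected to be small, with no direction resolved beyond the scatter. Compound 4 is estimated at 4500 nM (range 1800 nM to 11000 nM), the expected step being a 1.1-fold higher number from compound 2 to compound 4 (0.05 log units; within the scatter).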

Compound 4, concentration for total growth inhibition: 3380 nM
Beside the measured number, compound 4's estimate is 1.3-fold (0.12 log units) above it; the range from low to high includes it.
By their numbers in this assay, from the lowest: compounds 4, 1, 2 and 3 (each within the scatter of the next).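

In this assay, for the compounds shown here, the step from chloro to hydrogen on the aromatic carbon between two ring nitrogen atoms is isolated for the first time, as a 1.2-fold lower number from compound 2 to compound 4 (0.07 log units; within the scatter) within the usual scatter. Compound 2 and compound 4 therefore cannot be told apart, and chloro at this position is not required for growth inhibition at this level. No measurement shown explains this result.

Going by these compounds, an amine or a methoxy group at this position remains open. So does replacement of the remaining chloro group, which sits meta to this position.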